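Shifting the chlorine on the benzoyl amide of compound 1

The compounds below may be only part of what the source reports. "The series", "measured", "known", "first", "only" and "open" are said of these compounds alone.

Compound 1 `O=C(Nc1ccccc1O)C1CCc2ccccc2N1C(=O)c1ccccc1Cl` — 47400 nM
Compound 2 `CCCC(=O)N1c2ccccc2CCC1C(=O)Nc1cc(C(F)(F)F)cc(C(F)(F)F)c1` — 15200 nM
Compound 3 `CCC(=O)N1c2ccccc2CCC1C(=O)Nc1ccccc1C(F)(F)F` — a limit, > 80000 nM

In a functional assay on MDA-MB-231 cells (Homo sapiens) for cytotoxicity, read by sulforhodamine B assay, with a stated time of 72 h (on this read-out lower numbers stand for stronger inhibition of growth and higher numbers for weaker inhibition of growth), compound 1 gives 47400 nM, the higher of the two numbers that were obtained; compound 2 sits lower, at 15200 nM, and the gap between them is beyond the usual scatter. For compound 3 the result is only a limit, > 80000 nM (the limit of > 80000 nM in this assay, at which 1 of the 3 values shown sits), so no number is known for it. Compound 4 `O=C(Nc1ccccc1O)C1CCc2ccccc2N1C(=O)c1cccc(Cl)c1` is not yet measured. It differs from compound 1 in one place: 3-chlorophenyl in place of 2-chlorophenyl on a carbonyl carbon. Going by the values given here, no measured pair shows this change, so no step beyond the scatter is expected in either direction. Compound 4 is expected to give roughly 40000 nM, between 15000 nM and 80000 nM, an expected step of a 1.2-fold lower number from compound 1 to compound 4 (0.07 log units; within the scatter).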

Compound 4, concentration for 50% growth inhibition: 10600 nM
Compound 4: middle estimate off by 3.8-fold (0.58 log units), on the high side, and the stated range ends above it.
By their numbers in this assay, from the lowest: compounds 4 and 2 (each within the scatter of the next); then compound 1. At a limit, above all of these: compound 3.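

Moving one chlorine, with the atoms of the molecule otherwise unchanged, is enough to alter growth inhibition: in this assay, 3-chlorophenyl in place of 2-chlorophenyl on a carbonyl carbon gives a 4.5-fold lower number from compound 1 to compound 4 (0.65 log units; beyond the scatter). So this position responds to where the chlorine sits, a modest effect that the earlier compounds, which differ in several places, could not isolate. Nothing measured here explains the change. Still open, as far as these compounds go, is whether an amine or a carboxylic acid in place of the chlorine would lower the number further, and whether the same shift would matter on a different amide group.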